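A few compounds are considered here, and "the series" means these few. Any claim that something is new, unique, unknown or untested is made for them only; others in the source may bear on it.

Measured so far in a functional assay on CHO cells for agonist activity at Alpha-1D adrenergic receptor (Homo sapiens), read by FLIPR and calcium flux; a higher number here means that more compound is needed for the effect, a lower number that less compound is needed:
compound 1 `Clc1ccc2c(c1-c1ccn[nH]1)CCC2c1ncc[nH]1` — > 10000 nM (a limit of this assay)
compound 2 `COc1c(Cl)ccc2c1CCC2c1ncc[nH]1` — > 10000 nM (a limit of this assay)
compound 3 `c1cc(-c2cn[nH]c2)c2c(c1)C(c1ncc[nH]1)CC2` — 319 nM

Within the data shown here, compound 3 carries the only number in the set; the two other values are limits. For compound 1 the value > 10000 nM is a limit of this assay and not a number. For compound 2 the value > 10000 nM is likewise a limit. Two of the three values therefore sit at the limit of > 10000 nM in this assay, at which 2 of the 3 values shown sit.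

Compound 4 `Clc1ccc2c(c1-c1cn[nH]c1)CCC2c1ncc[nH]1` differs from compound 3 by chloro in place of hydrogen on an aromatic carbon. Among the measured compounds shown here, the only step between measured compounds, a step that the two limits leave unreadable from compound 1 to compound 2, is unreadable because both ends are limits, so it gives no size for any change. For the measured compounds named here, no measured step covers a chloro entering on this ring; the nearest comparison is compound 1, which also carries a chloro and sits at the limit, though it differs from compound 3 elsewhere as well.

For compound 4 a loss in this assay is expected, a 4.7-fold higher number from compound 3 to compound 4 (0.67 log units; beyond the scatter), with a real chance that only a limit is returned. The estimate for compound 4 is 1500 nM, within 300 nM to 10000 nM.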

Compound 4, half-maximal effective concentration: > 10000 nM
Compound 4 was reported as a limit; the forecaster's own chance of this, stated with the estimate: 35%; middle value at least 6.6-fold (0.82 log units) from the limit.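

In this assay, among these compounds, chloro in place of hydrogen on the aromatic carbon ortho to the 1H-pyrazol-4-yl group gives the first step of readable size (an at least 31-fold higher number from compound 3 to compound 4 (1.49 log units; beyond the scatter)), and this one change is enough to turn a number into a limit. Compound 4 returns a limit and not a number, so that step gives only the smallest possible size of the loss: the limit of > 10000 nM in this assay, at which 3 of the 4 values shown sit. All three chloro compounds shown now stand at this limit, the compound without chloro carries the only number, and no compound shown goes against this, while the steps from compound 1 and from compound 2 to compound 4 cannot be read.

On these data alone, whether fluoro, methyl or an amine at this position keeps a number in this assay stays open. Also open, as far as these compounds go, is whether the 1H-pyrazol-5-yl group gives a number without the chloro.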